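Aryl variation on the pyrazole carboxylic acid series

The compounds below may be only part of what the source reports. "The series", "measured", "known", "first", "only" and "open" are said of these compounds alone.

Measured compounds in a functional assay on BJAB cells (Homo sapiens) for antiproliferative activity, with a stated time of 4 days; a lower number here means that less compound is needed, a higher number that more compound is needed for the effect:
compound 1 `COc1cccc(-c2c(C)nn(-c3nc(-c4ccc(Cl)c(Cl)c4)c(SC(C)C)s3)c2C(=O)O)c1`, 14000 nM
compound 2 `Cc1nn(-c2nc(-c3ccc(Cl)c(Cl)c3)c(SC(C)C)s2)c(C(=O)O)c1-c1cnccn1`, 14000 nM
compound 3 `CCOc1ncccc1-c1c(C)nn(-c2nc(-c3ccc(Cl)c(Cl)c3)c(SC(C)C)s2)c1C(=O)O`, 11000 nM

Compound 1 stands level with compound 2 at the digits shown, and the two together hold the highest numbers of the three; compound 3 lies nearest to them, with only a 1.3-fold lower number from compound 1 to compound 3 (0.10 log units; within the scatter) separating it from compound 1. Every step among the measured compounds stays within the scatter: no change at the digits printed from compound 1 to compound 2 (within the scatter) and a 1.3-fold lower number from compound 2 to compound 3 (0.10 log units; within the scatter) are as small as the step already named. In short, exchanging the aromatic group at this carbon of the shared core has so far moved nothing beyond the noise.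

Compound 4 `Cc1ccc(-c2c(C)nn(-c3nc(-c4ccc(Cl)c(Cl)c4)c(SC(C)C)s3)c2C(=O)O)cc1` is the next variation at the same place. Its difference from compound 1 is 4-methylphenyl in place of 3-methoxyphenyl on an aromatic carbon. Within the data shown here, no measured step removes the hydrogen-bond acceptor in this way, so the three small steps are the only guide; they all point to no change beyond the scatter, and the same is expected for no change at the digits printed from compound 1 to compound 4 (within the scatter) in this assay.

Compound 4 is therefore estimated at 14000 nM, with a range from 6000 nM to 32000 nM, the width covering the possibility that the number drifts either way.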

Compound 4, half-maximal effective concentration: 3800 nM
Compound 4: middle estimate off by 3.7-fold (0.57 log units), on the high side, and the stated range ends above it.
By their numbers in this assay, from the lowest: compound 4; then compounds 3, 1 and 2 (each within the scatter of the next).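

In this assay this position proves able to respond after all: 4-methylphenyl in place of 3-methoxyphenyl gives a 3.7-fold lower number from compound 1 to compound 4 (0.57 log units; beyond the scatter), and the same group also stands apart from the other two aromatic groups, with a 2.9-fold lower number from compound 3 to compound 4 (0.46 log units; beyond the scatter) and a 3.7-fold lower number from compound 2 to compound 4 (0.57 log units; beyond the scatter). Among these compounds, compounds 1, 2 and 3 remain within the scatter of one another, so the response at this carbon rests on compound 4 alone and is no general trend across aromatic groups; the single exchange also changes two things at once, as the 3-methoxy group is lost and a methyl group enters at the 4-position of the phenyl ring, and the step cannot divide its size between them. Nothing at hand bears on why this exchange lowers the number.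

The compounds shown leave open whether the methyl group, its place on the phenyl ring or the loss of the methoxy group carries the step, a question that 3-methylphenyl and 4-methoxyphenyl at this carbon would address directly. Also open, going by these compounds, is whether a longer chain such as 4-ethylphenyl, or an amine such as 4-aminophenyl, would hold, extend or lose the lower number.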